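A few compounds are considered here, and "the series" means these few. Any claim that something is new, unique, unknown or untested is made for them only; others in the source may bear on it.

Measured so far:
compound 1 `O=c1[nH]cnc2c1c(-c1ccoc1)cn2[C@@H]1O[C@H](CO)[C@@H](O)[C@H]1O` — 14800 nM
compound 2 `O=c1[nH]cnc2c1c(-c1ccsc1)cn2[C@@H]1O[C@H](CO)[C@@H](O)[C@H]1O` — > 20000 nM

In a functional assay on HCT-116 cells (Homo sapiens), read by MTT assay, with a stated time of 72 h (on this read-out lower numbers stand for stronger inhibition and higher numbers for weaker inhibition), compound 1 gives 14800 nM. For compound 2 the read-out is only a limit of the assay, > 20000 nM (the limit of > 20000 nM in this assay, at which 1 of the 2 values shown sits). Going by the values given here, the one measured step is an at least 1.3-fold higher number from compound 1 to compound 2 (0.13 log units; that floor lies within the scatter), so compound 2 stands at the weak end, at the limit.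

Compound 3 `O=c1[nH]cnc2c1c(-c1ccccc1)cn2[C@@H]1O[C@H](CO)[C@@H](O)[C@H]1O` arises from compound 2 by phenyl in place of thiophen-3-yl on an aromatic carbon. Among the compounds with values here, no measured step covers this change; the step from furan-3-yl to thiophen-3-yl stayed within the scatter, and no step beyond the scatter is expected here. Compound 3 is estimated at 25000 nM, range 12000 nM to 60000 nM, expected as a step that the limit leaves unreadable from compound 2 to compound 3, most likely again a limit.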

Compound 3, half-maximal inhibitory concentration: > 20000 nM
Compound 3: no number, only a limit (the forecaster's own chance of this, stated with the estimate: 65%); the middle value does not contradict the limit.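

With phenyl at this place, a six-membered ring of carbon only joins the five-membered rings, and the read-out in this assay again gives no number: compound 3 sits at a limit, > 20000 nM. Against furan-3-yl, the change gives an at least 1.3-fold higher number from compound 1 to compound 3 (0.13 log units; that floor lies within the scatter), so no separation from compound 1 can be claimed. The step between the thiophen-3-yl and phenyl compounds cannot be read: the limit of > 20000 nM in this assay, at which 2 of the 3 values shown sit.

Going by these compounds, how far compound 2 and compound 3 lie past the limit stays open. Also open, on these data alone, is whether an amine, a carboxylic acid or a longer chain at this place would give a measurable number.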